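Replacing the Azetidine Ring on the Sulfonyl Group

The compounds below may be only part of what the source reports. "The series", "measured", "known", "first", "only" and "open" are said of these compounds alone.

Of the compounds shown here, three sharing one core have been tested in an assay on isolated protein for inhibition of Indoleamine 2,3-dioxygenase 1 (Homo sapiens), read by fluorescence, with a stated time of 60 min; a higher number here means a weaker inhibitor, a lower number a stronger inhibitor. Compound 1 `[O-][S+]1CC(Nc2nonc2/C(=N/O)Nc2ccc(F)c(Br)c2)C1` gives 212 nM, compound 2 `N=S1(=O)CC(Nc2nonc2/C(=N/O)Nc2ccc(F)c(Br)c2)C1` gives 208 nM, and compound 3 `O=S(=O)(CCNc1nonc1/C(=N/O)Nc1ccc(F)c(Br)c1)N1CCC1` gives 191 nM. Compound 3 holds the lowest of the three numbers, but the steps of a 1.1-fold lower number from compound 1 to compound 3 (0.05 log units; within the scatter) and a 1.1-fold lower number from compound 2 to compound 3 (0.04 log units; within the scatter) both lie within the scatter, as does a 1.0-fold lower number from compound 1 to compound 2 (0.01 log units; within the scatter). Compound 4 `NNS(=O)(=O)CCNc1nonc1/C(=N/O)Nc1ccc(F)c(Br)c1` differs from compound 3 by aminoamino in place of azetidin-1-yl on a sulfonyl sulfur. For the measured compounds named here, every measured step so far altered the group attached to the nitrogen on the aromatic ring and left this assay essentially unmoved, so the step of a 1.0-fold higher number from compound 3 to compound 4 (0.02 log units; within the scatter) is expected to be small in either direction. Compound 4 is therefore estimated at 200 nM, with a range from 100 nM to 400 nM.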

Compound 4, half-maximal inhibitory concentration: 135 nM
Compound 4: middle estimate off by 1.5-fold (0.17 log units), on the high side, within the range that was stated.
By their numbers in this assay, from the lowest: compounds 4, 3, 2 and 1 (each within the scatter of the next).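

For the compounds shown here, the first change at the sulfonyl sulfur, from the azetidin-1-yl ring to the ringless aminoamino, gives a step within the scatter in this assay (a 1.4-fold lower number from compound 3 to compound 4 (0.15 log units; within the scatter)). The comparisons with the other two compounds also lie within the scatter (a 1.5-fold lower number from compound 2 to compound 4 (0.19 log units; within the scatter); a 1.6-fold lower number from compound 1 to compound 4 (0.20 log units; within the scatter)), so removing the ring and adding hydrogen-bond donors at this place gives no readable difference. No supporting data bear on this result.

Still open, going by these compounds, is whether an amine or a carboxylic acid on the sulfonyl sulfur would give a step beyond the scatter.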